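Adding a Methoxy Group to the Phenoxy Tail of Compound 3

The source may report more compounds than this note shows. Statements on the series, on what has been measured and on what is new or still open speak of the compounds shown alone.

Measured compounds:
compound 1, `CC1CC(=O)N(c2ccccc2C(=O)OCC2CCCN(CCCCOc3ccc(Cl)c(Cl)c3)C2)C1=O`, which in an in vitro functional assay on HEK ts201 cells for antagonist activity at Neuronal acetylcholine receptor; alpha4/beta2 (Homo sapiens), read by fluorescence and calcium flux (a lower number here means a stronger inhibitor, a higher number a weaker inhibitor), gives 12300 nM
compound 2, `COc1cccc(OCCCCCN2CCCC(COC(=O)c3ccccc3N3C(=O)CC(C)C3=O)C2)c1OC`, which gives 8710 nM
compound 3, `CC1CC(=O)N(c2ccccc2C(=O)OCC2CCCN(CCCCCOc3ccccc3)C2)C1=O`, which gives 17000 nM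

Compound 3 has the highest of the three numbers, yet neither gap takes it beyond the scatter: a 1.4-fold higher number from compound 1 to compound 3 (0.14 log units; within the scatter), and a 2.0-fold higher number from compound 2 to compound 3 (0.29 log units; within the scatter). The third pair behaves the same way, with a 1.4-fold lower number from compound 1 to compound 2 (0.15 log units; within the scatter). All three compounds share the same core and differ only in the aryl group at the end of the chain, and none of these changes to that aryl group has moved the number beyond the scatter.

Compound 4, `COc1ccc(OCCCCCN2CCCC(COC(=O)c3ccccc3N3C(=O)CC(C)C3=O)C2)cc1`, differs from compound 3 by methoxy in place of hydrogen on an aromatic carbon, so that phenoxymethyl becomes (4-methoxyphenoxy)methyl. For the measured compounds named here, the step that bears most directly on this is the one between compound 2 and compound 3, where a 2,3-dimethoxyphenyl replaced a phenyl on the same oxygen and a 2.0-fold higher number from compound 2 to compound 3 (0.29 log units; within the scatter). A single methoxy on the same ring is a smaller change still, and the other two aryl variations were likewise within the scatter. Compound 4 is therefore expected to sit close to compound 3, with a 1.3-fold lower number from compound 3 to compound 4 (0.12 log units; within the scatter) not expected to exceed the scatter. The estimate for compound 4 in this assay is 13000 nM, with a range from 5000 nM to 35000 nM.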

Compound 4, half-maximal inhibitory concentration: 14500 nM
Compound 4: middle estimate off by 1.1-fold (0.05 log units), on the low side, within the range that was stated.
By their numbers in this assay, from the lowest: compounds 2, 1, 4 and 3 (each within the scatter of the next).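

In this assay, for the compounds shown here, methoxy in place of hydrogen on an aromatic carbon, para to a large group, gives a 1.2-fold lower number from compound 3 to compound 4 (0.07 log units; within the scatter) and so isolates one group at one place on the six-membered aromatic ring, where the earlier steps exchanged whole aryl ends carrying two substituents or none. Going by these compounds alone, compound 4 also stays close to the two more heavily substituted tails, with a 1.7-fold higher number from compound 2 to compound 4 (0.22 log units; within the scatter) and with a 1.2-fold higher number from compound 1 to compound 4 (0.07 log units; within the scatter) so that no step among the four compounds lies beyond the scatter, and the phenyl, 4-methoxyphenyl, 2,3-dimethoxyphenyl and 3,4-dichlorophenyl ends cannot be placed in any order. Nothing available explains why these tails remain within the scatter of one another.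

The compounds shown leave open whether an amine or a carboxylic acid in place of the methoxy on this carbon would give a step beyond the scatter, or whether the same would hold for a hydroxy group or a fluorine atom. They also leave open whether a longer chain leading to the aryl end, or a new group on the shared core, would move the number further than any of these aryl changes has.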